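This account rests on a few compounds, and the source may have more. Where it says the series, first, only, none or still open, it means among the compounds named here.

Two members of the series carry numbers in a functional assay on the whole organism (Tail, strain ICR) with Mus musculus as the target, in the tail flick test, with a stated time of 120 min, at a dose of 25 umol/kg by the oral route; on this read-out lower numbers stand for a weaker effect and higher numbers for a stronger effect at the one dose given. Compound 1 , `CC[C@H](C)[C@H](NC(=O)CN(c1ncnc2c1ncn2C1CCCCO1)C1CC1)C(=O)OCc1ccccc1`, gives 20.4% in this assay and stands lowest of the two. Within the data shown here, compound 2 , `C[C@@H](O)[C@H](NC(=O)CN(c1nc(Cl)nc2[nH]cnc12)C1CC1)C(=O)OCc1ccccc1`, gives 30.7% in this assay, a number beyond the scatter above that of compound 1; the two structures differ in more than one place, so their values show only that compound 2 is the higher of the pair. The next compound is compound 3 , `NC(=O)C[C@H](NC(=O)CN(c1ncnc2c1ncn2C1CCCCO1)C1CC1)C(=O)OCc1ccccc1`, not yet measured in this assay. Compound 3 differs from compound 1 in one place: carbamoylmethyl in place of sec-butyl on a saturated chain carbon bound to an amide-type nitrogen and a carbonyl carbon. Among the measured compounds shown here, no step between two measured compounds that differ in a single place is available, and nothing tells how a change on that chain carbon moves the read-out. The expectation therefore rests on compound 1 alone, whose 20.4% serves as the anchor. The expected step is a number 0.6 percentage points higher from compound 1 to compound 3 (within the scatter), none beyond the scatter. Compound 3 is expected to give about 21% in this assay, with a range from 8% to 36%.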

Compound 3, a percentage reported as activity, at one dose (the size of the read-out at that dose, not a potency): 29.2%
Compound 3: the middle estimate sits 8.2 percentage points below what was measured; measured number inside the range.
By their numbers in this assay, from the lowest: compounds 1, 3 and 2 (each within the scatter of the next, the first and the last beyond it).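

On the saturated chain carbon bound to an amide-type nitrogen and a carbonyl carbon, carbamoylmethyl in place of sec-butyl gives a number 8.8 percentage points higher from compound 1 to compound 3 (within the scatter) in this assay, the first single-place step available in this series. At this position, then, a chain with no hydrogen-bond donor or acceptor and one that carries both cannot be told apart on this read-out at the one dose given, so this change gives no sign that the position governs the effect. Nothing measured accounts for this result, and one step does not establish a trend at this position.

From the compounds shown here alone, whether a carboxylic acid, a primary amine or a longer alkyl chain on the same carbon would give a step beyond the scatter remains open. Going by these compounds, it is also open whether carbamoylmethyl in place of sec-butyl would give a similar step on a different core, and whether the read-out at other doses or times would separate the two groups.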